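Working notes: replacing bromo with dimethylamino

This account rests on a few compounds, and the source may have more. Where it says the series, first, only, none or still open, it means among the compounds named here.

compound 1 `COc1ccc(C(=O)c2ccc(OC)c3c2OC(C)(C)C=C3)c(NC(=O)CBr)c1`: 1210 nM
compound 2 `CCNCC(=O)Nc1cc(OC)ccc1C(=O)c1ccc(OC)c2c1C=CC(C)(C)O2`: 2310 nM

In a functional assay on A549 cells (Homo sapiens) for antiproliferative activity, read by MTT assay, with a stated time of 48 h (on this read-out higher numbers stand for weaker inhibition and lower numbers for stronger inhibition), compound 1 gives 1210 nM and compound 2 gives 2310 nM. Within the data shown here, these two values lie within the usual scatter of each other, so compound 1 stands level with the only other measured compound. Compound 3 `COc1ccc(C(=O)c2ccc(OC)c3c2OC(C)(C)C=C3)c(NC(=O)CN(C)C)c1` keeps the core of compound 1 and carries dimethylamino in place of bromo on a saturated chain carbon bound to a carbonyl carbon. Among the measured compounds shown here, no measured pair shows this change on its own, so the expectation is loose. Compound 2 at 2310 nM also has no bromo on that chain, and its value is not separated from that of compound 1 beyond the scatter. In this assay, only a small rise in the number is therefore expected, meaning slightly weaker inhibition. The expected step is a 1.7-fold higher number from compound 1 to compound 3 (0.22 log units; within the scatter). The estimated value for compound 3 is 2000 nM, with an expected range from 700 nM to 6000 nM.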

Compound 3, half-maximal inhibitory concentration: 890 nM
Compound 3: the middle estimate sits 2.2-fold (0.35 log units) above what was measured; the measured number falls inside the stated range.
By their numbers in this assay, from the lowest: compounds 3, 1 and 2 (each within the scatter of the next, the first and the last beyond it).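

In this assay, among these compounds, the exchange of bromo for dimethylamino on a saturated chain carbon bound to a carbonyl carbon gives a 1.4-fold lower number from compound 1 to compound 3 (0.13 log units; within the scatter), the first reading of this change on its own. At this position, bromo can therefore give way to dimethylamino on the core of compound 1 with no separation between the two values beyond the scatter. Nothing available accounts for this outcome.

On these data alone, whether a cyclic amine such as morpholine or piperidine, or a longer chain carrying the dimethylamino group, would separate from compound 3 beyond the scatter remains open. Compound 2 differs from both compound 1 and compound 3 in more than one place, so the effect of its ethylamino group alone also remains unresolved.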